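The source may hold more compounds than are shown below. What is called first, only, known or untested is meant among the compounds shown, and "the series" means these compounds.

Measured compounds in a functional assay on NCI-H460 cells (Homo sapiens) for cytotoxicity, read by MTT assay; a lower number here means a stronger inhibitor, a higher number a weaker inhibitor:
compound 1 `COc1cc(/C=C/C(=O)c2sc(Nc3ccc(Cl)cc3)nc2C)cc(OC)c1OC` gives 22000 nM;
compound 2 `Cc1nc(Nc2cccc(Cl)c2)sc1C(=O)/C=C/c1ccc(Cl)cc1` gives only a limit, > 25000 nM;
compound 3 `COc1cc(/C=C/C(=O)c2sc(Nc3cccc(Cl)c3)nc2C)cc(OC)c1OC` gives only a limit, > 25000 nM.

Compound 3 therefore stands at the weak end of what was measured: its value is a limit of this assay, not a number, and it shares the limit of > 25000 nM in this assay, at which 2 of the 3 values shown sit, with compound 2. Within the data shown here, the only step computed among the measured compounds, an at least 1.1-fold higher number from compound 1 to compound 3 (0.05 log units; that floor lies within the scatter), moves from a number to that limit, so its true size is unknown.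

Compound 4 `COc1cc(/C=C/C(=O)c2sc(Nc3ccc(Cl)c(Cl)c3)nc2C)cc(OC)c1OC` differs from compound 3 by chloro in place of hydrogen on an aromatic carbon. No measured step touches the addition of a chloro group on this ring, so nothing shown points to a change in either direction. With compound 3 already at the limit in this assay, the expectation is that compound 4 remains near or beyond that limit, and the step from compound 3 to compound 4 is estimated as a number no higher from compound 3 to compound 4 (the limit leaves the size open). Compound 4 is thus expected to give about 25000 nM, within 8000 nM to 60000 nM.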

Compound 4, half-maximal inhibitory concentration: > 25000 nM
Compound 4: no number, only a limit; the forecaster's own chance of this, stated with the estimate: 60%; the middle value sits exactly at the limit.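

In this assay compound 4 gives > 25000 nM, which is a limit of the assay and not a number. Among these compounds, the steps between the two compounds at the limit cannot be read, so the 3,4-dichlorophenyl group in place of 3-chlorophenyl has no measurable size here, and the one readable comparison, with the only compound that has a number, is an at least 1.1-fold higher number from compound 1 to compound 4 (0.05 log units; that floor lies within the scatter). A second chloro group on this ring therefore brought no number into the measured range, and the compounds now gather at one end of the scale: the limit of > 25000 nM in this assay, at which 3 of the 4 values shown sit.

On these data alone, how far compound 2, compound 3 and compound 4 lie from one another past this limit remains open. Also open, as far as these compounds go, is whether an amine or a carboxylic acid at this place on the ring, in place of chloro, would give a number.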